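The source may hold more compounds than are shown below. What is called first, only, known or untested is meant among the compounds shown, and "the series" means these compounds.

For the measured compounds named here, in a functional assay on MGC-803 cells (Homo sapiens) for inhibition, read by MTT assay, with a stated time of 72 h (a lower number here means a stronger inhibitor, a higher number a weaker inhibitor), compound 3 `C=CC(=O)Nc1cccc(NC(=O)CSc2nc(Nc3ccccc3)c3ccccc3n2)c1` gives 7310 nM and stands lowest of the three numbers known. Compound 1 `O=C(CSc1nc(Nc2ccccc2)c2ccccc2n1)Nc1ccccc1F` gives 10700 nM in this assay, and the step of a 1.5-fold lower number from compound 1 to compound 3 (0.17 log units; within the scatter) is within the scatter, so no order between compound 1 and compound 3 can be claimed. Compound 2 `O=C(CSc1nc(Nc2ccccc2)c2ccccc2n1)Nc1ccccc1Cl` gives 24800 nM in this assay, and the step of a 3.4-fold lower number from compound 2 to compound 3 (0.53 log units; beyond the scatter) is beyond the scatter. The remaining measured step is a 2.3-fold higher number from compound 1 to compound 2 (0.37 log units; beyond the scatter).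

Compound 4 `O=C(CSc1nc(Nc2ccccc2)c2ccccc2n1)Nc1ccc([N+](=O)[O-])cc1` differs from compound 3 only in the group on the amide-type nitrogen: 4-nitrophenyl in place of 3-((vinylcarbonyl)amino)phenyl on an amide-type nitrogen. The steps of a 1.5-fold lower number from compound 1 to compound 3 (0.17 log units; within the scatter) and a 3.4-fold lower number from compound 2 to compound 3 (0.53 log units; beyond the scatter) bear on this place, and both show that the group on this nitrogen moves the number by a modest amount at most. Going by the values given here, no measured compound carries a nitro group, so the direction of the change to compound 4 rests on thin ground. The step to compound 4 is therefore expected to be small, a 1.6-fold higher number from compound 3 to compound 4 (0.22 log units; within the scatter), most likely a somewhat higher number in this assay. Compound 4 is estimated at 12000 nM in this assay, with a range from 4500 nM to 35000 nM.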

Compound 4, half-maximal inhibitory concentration: > 50000 nM
Compound 4: no number, only a limit; the forecaster's own chance of this, stated with the estimate: 8%; middle value at least 4.1-fold (0.61 log units) from the limit.
By their numbers in this assay, from the lowest: compounds 3 and 1 (each within the scatter of the next); then compound 2. At a limit, above all of these: compound 4.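

In this assay compound 4 gives no number, only a limit of the assay: the limit of > 50000 nM in this assay, at which 1 of the 4 values shown sits. The earlier changes on the amide-type nitrogen gave modest steps at most, whereas 4-nitrophenyl gives an at least 6.8-fold higher number from compound 3 to compound 4 (0.83 log units; beyond the scatter) and an at least 4.6-fold higher number from compound 1 to compound 4 (0.66 log units; beyond the scatter), so this place can weaken the compounds further than those changes showed. Against 2-chlorophenyl the result reads only as an at least 2.0-fold higher number from compound 2 to compound 4 (0.30 log units; that floor lies within the scatter), so compound 4 is not clearly separated from compound 2.

On these data alone, how far the true value of compound 4 lies past the limit stays open. Also open, as far as these compounds go, is whether the nitro group itself sets this result or whether other groups on the same ring would do the same, as a 4-aminophenyl or 4-methoxyphenyl group on this nitrogen would show.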